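Adding Methylsulfanyl to a Compound Stuck at the Assay Limit

The source may report more compounds than this note shows. Statements on the series, on what has been measured and on what is new or still open speak of the compounds shown alone.

Compound 1 `CCCCC[Se]c1nc(NCc2ccc(SC)cc2)c2ccccc2n1`: in a functional assay on HT-29 cells (Homo sapiens) for cytotoxicity, read by MTT assay, with a stated time of 72 h (on this read-out lower numbers stand for stronger inhibition of growth and higher numbers for weaker inhibition of growth), compound 1 gives > 100000 nM, which is a limit of the assay rather than a number.
Compound 2 `CSc1nc(NCc2ccc([Se]C)cc2)c2ccccc2n1`: in this assay compound 2 gives > 100000 nM, again a limit.
Compound 3 `CSc1nc(NCc2ccccc2)c2ccccc2n1`: in this assay compound 3 gives > 100000 nM, also a limit.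

Compound 3 therefore stands where every measured compound stands, at the limit of > 100000 nM in this assay, at which 3 of the 3 values shown sit, and the numbers shown give it no position apart from its two companions. The next compound, compound 4 `CSc1ccc(CNc2nc(SC)nc3ccccc23)cc1`, differs from compound 3 by methylsulfanyl in place of hydrogen on an aromatic carbon. Among the compounds with values here, only one measured step touches this part of the molecule, a step that the two limits leave unreadable from compound 2 to compound 3, whose two ends are both limits, so its size cannot be read. With no readable step and all three values at the limit, there is no ground to expect a change in this assay beyond the scatter. The expected step is a step that the limit leaves unreadable from compound 3 to compound 4, which amounts to none. For compound 4 the expected result is 150000 nM, within an estimated range from 50000 nM to 500000 nM. Compound 4 is most likely again expected to be reported only as a limit.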

Compound 4, concentration for total growth inhibition: > 100000 nM
Compound 4: only a limit was reported; the forecaster's own chance of this, stated with the estimate: 85%; the middle value lies beyond the limit too.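

The result for compound 4 is a limit, not a number, so its steps from compound 1, compound 2 and compound 3 cannot be read: the limit of > 100000 nM in this assay, at which 4 of the 4 values shown sit. The compounds shown leave open whether methylsulfanyl in place of hydrogen changes growth inhibition at all.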